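Lengthening the Chain from Compound 3 to Compound 4

The source may report more compounds than this note shows. Statements on the series, on what has been measured and on what is new or still open speak of the compounds shown alone.

Four compounds share one core and differ only in the group carried on a saturated chain carbon bound to an aromatic nitrogen. In an assay on isolated protein (Oryctolagus cuniculus) with Thromboxane-A synthase (Homo sapiens) as the target, tested at 1 uM (a higher number here means more inhibition at the concentration tested (going by the name of the read-out), a lower number less inhibition), compound 1 `CCCn1nc(-c2cccnc2)c2ccccc2c1=O` gives 86%, compound 2 `C=CCn1nc(-c2cccnc2)c2ccccc2c1=O` gives 70%, and compound 3 `CC(=O)Cn1nc(-c2cccnc2)c2ccccc2c1=O` gives 13%. Compound 3 stands lowest of the three: its nearest neighbour is compound 2, and the distance to compound 1 is larger still. The two steps that lead into compound 3 are both large, a number 73 percentage points lower from compound 1 to compound 3 (beyond the scatter) and a number 57 percentage points lower from compound 2 to compound 3 (beyond the scatter), while the step of a number 16 percentage points lower from compound 1 to compound 2 (beyond the scatter) is modest.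

Compound 4 `CCOC(=O)CCCn1nc(-c2cccnc2)c2ccccc2c1=O` has not been measured in this assay. It differs from compound 3 in a single place: 2-(ethoxycarbonyl)ethyl in place of acetyl on a saturated chain carbon bound to an aromatic nitrogen. Both steps that bring in acetyl were large falls, and compound 4 no longer carries acetyl; compound 1, with an ethyl at the same chain carbon, stands highest. For compound 4 a rise is therefore expected, with the estimated step of a number 42 percentage points higher from compound 3 to compound 4 (beyond the scatter) and a value near 55%, lying between 25% and 85%.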

Compound 4, a percentage reported as inhibition, at one concentration (the size of the read-out at that concentration, not a potency): 95%
The estimate for compound 4 lay 40 percentage points below the measured number; measured number above the stated range.
By their numbers in this assay, from the lowest: compound 3; then compound 2; then compounds 1 and 4 (each within the scatter of the next).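

In this assay, the large fall seen with acetyl does not extend to every chain holding a carbonyl at this place: 2-(ethoxycarbonyl)ethyl gives a number 82 percentage points higher from compound 3 to compound 4 (beyond the scatter). The same group gives a number 25 percentage points higher from compound 2 to compound 4 (beyond the scatter), and adding ethoxycarbonyl to the end of the chain of compound 1 gives a number 9 percentage points higher from compound 1 to compound 4 (within the scatter), which leaves compound 1 and compound 4 level. The position thus accepts the longer 3-(ethoxycarbonyl)propyl chain with no loss against compound 1, and among these four compounds the low number belongs to the 2-oxopropyl group of compound 3 alone, not to carbonyl-bearing chains in general.

From the compounds shown here alone, it remains open whether a carboxylic acid, an amide or an amine at the end of this chain would hold the number, and whether a plain butyl chain would do the same. Nothing available here gives a reason for the wide gap between these two groups.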